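The source may report more compounds than this note shows. Statements on the series, on what has been measured and on what is new or still open speak of the compounds shown alone.

Working notes on the series. Compound 2 `CC1(Cc2cccc(C(F)(F)F)c2)CC(S(=O)(=O)c2ccc(F)cc2)=C(c2ccc(/C(N)=N/O)cc2)O1` was tested in an ADME assay on cells (Peritoneal macrophage, Mus musculus, strain Balb/c) for cytotoxicity, read by resazurin assay, with a stated time of 72 h (on this read-out lower numbers stand for higher toxicity in this test and higher numbers for lower toxicity in this test), and gives 49800 nM. Compound 1 `CC1(Cc2ccc(C(F)(F)F)cc2)CC(S(=O)(=O)c2ccc(F)cc2)=C(c2ccc(/C(N)=N/O)cc2)O1` gives 103000 nM. Among the measured compounds shown here, on these two numbers compound 2 stands lowest; its nearest neighbour is compound 1, and the step of a 2.1-fold lower number from compound 1 to compound 2 (0.32 log units; beyond the scatter) is the only measured step in the set.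

Compound 3 `COc1cc(CC2(C)CC(S(=O)(=O)c3ccc(F)cc3)=C(c3ccc(/C(N)=N/O)cc3)O2)cc(OC)c1OC` is not yet measured. Its change from compound 2: 3,4,5-trimethoxyphenyl in place of 3-(trifluoromethyl)phenyl on a saturated chain carbon bound to a saturated ring carbon.

For the measured compounds named here, the one measured step, a 2.1-fold lower number from compound 1 to compound 2 (0.32 log units; beyond the scatter), concerns a shift of the trifluoromethyl group around its ring and does not exchange one substituent pattern for another, so no measured step bears directly on the change from compound 2 to compound 3. With nothing in the data pointing either way, the step of a 1.2-fold higher number from compound 2 to compound 3 (0.08 log units; within the scatter) in this assay is expected to stay within the scatter, in no particular direction. Going by the values given here, compound 3 is therefore expected to give about 60000 nM in this assay, with a wide range from 20000 nM to 160000 nM reflecting that this exchange has no measured precedent here.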

Compound 3, half-maximal cytotoxic concentration: 92300 nM
The estimate for compound 3 lay 1.5-fold (0.19 log units) below the measured number, within the range that was stated.
By their numbers in this assay, from the lowest: compounds 2, 3 and 1 (each within the scatter of the next, the first and the last beyond it).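

In this assay, 3,4,5-trimethoxyphenyl in place of 3-(trifluoromethyl)phenyl on a saturated chain carbon bound to a saturated ring carbon gives a 1.9-fold higher number from compound 2 to compound 3 (0.27 log units; within the scatter), and the same group in place of 4-(trifluoromethyl)phenyl gives a 1.1-fold lower number from compound 1 to compound 3 (0.05 log units; within the scatter). Among the compounds shown here, the earlier pair showed only that moving the trifluoromethyl group around its ring can carry the read-out beyond the scatter; these steps add that exchanging the whole substituent pattern at this position stays within the scatter from either of those compounds, so compound 3 cannot be ranked against compound 1 or compound 2. Nothing available explains why the read-out responds in this way at this position.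

On these data alone, all three compounds keep a substituted phenyl ring at this position, so it remains open whether the read-out would hold with an unsubstituted phenyl, or with an amine or a carboxylic acid on that ring. As far as these compounds go, a longer chain between the ring and the saturated ring carbon, and any change elsewhere on the shared core, also remain open in this assay.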